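A few compounds are considered here, and "the series" means these few. Any claim that something is new, unique, unknown or untested is made for them only; others in the source may bear on it.

Compound 1 `O=C(NO)c1ccc(NCc2nc(-c3ccc(Br)cc3)nn2-c2ccccc2)cc1`: 54.7%
Compound 2 `O=C(NO)c1ccc(NCc2nc(-c3ccccc3)nn2-c2cccc(Cl)c2)cc1`: 62.3%
Compound 3 `Cc1cccc(-n2nc(-c3ccccc3)nc2CNc2ccc(C(=O)NO)cc2)c1`: 66%

All three compounds share one core and were measured in an assay on Sf9 cells for inhibition of protein deacetylase HDAC6 (Homo sapiens), read by fluorescence, with a stated time of 40 min, tested at 100 nM; on this read-out lower numbers stand for less inhibition and higher numbers for more inhibition at the one concentration tested (going by the name of the read-out). Compound 1 gives the lowest of the three numbers; compound 2 sits within the scatter of it, while compound 3 lies beyond the scatter above it. Compound 4 `O=C(NO)c1ccc(NCc2nc(-c3ccc(C(F)(F)F)cc3)nn2-c2ccccc2)cc1` has not been measured. It differs from compound 1 by trifluoromethyl in place of bromo on an aromatic carbon. Going by the values given here, the only measured step between compounds that differ in one place is a number 3.7 percentage points higher from compound 2 to compound 3 (within the scatter), which concerns a different change, so nothing measured bears directly on this exchange. For compound 4 a step of no more than the scatter is therefore expected, a number 1.7 percentage points lower from compound 1 to compound 4 (within the scatter). Compound 4 is estimated at 53%, with a range from 39% to 67%.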

Compound 4, a percentage reported as inhibition, at one concentration (the size of the read-out at that concentration, not a potency): 41.6%
The estimate for compound 4 lay 11.4 percentage points above the measured number; the range from low to high includes it.
By their numbers in this assay, from the lowest: compound 4; then compounds 1, 2 and 3 (each within the scatter of the next, the first and the last beyond it).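

Going by these compounds alone, exchanging 4-bromophenyl for 4-(trifluoromethyl)phenyl gives the first measured change at this position, and in this assay it produces a number 13.1 percentage points lower from compound 1 to compound 4 (beyond the scatter). The position is therefore not indifferent to what it carries: two groups with no hydrogen-bond donors or acceptors, one of 1 heavy atom and one of 4, give clearly different numbers. No measurement at hand explains this drop.

Going by these compounds, how an amine, a methoxy group or a carboxylic acid would read at this place remains open. Also open, on these data alone, is whether the same exchange would give a similar step elsewhere on the shared core.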